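Changing the Sulfonyl Substituent and Clearance in Rat Liver Microsomes

A few compounds are considered here, and "the series" means these few. Any claim that something is new, unique, unknown or untested is made for them only; others in the source may bear on it.

Compound 1, `COCCNS(=O)(=O)c1ccc(C)c(C#Cc2cc(Cl)ccc2OCC(=O)O)c1`: < 10 mL.min-1.g-1
Compound 2, `Cc1ccc(S(C)(=O)=O)cc1C#Cc1cc(Cl)ccc1OCC(=O)O`: 18 mL.min-1.g-1
Compound 3, `CN(C)S(=O)(=O)c1ccc(F)c(C#Cc2cc(Cl)ccc2OCC(=O)O)c1`: < 10 mL.min-1.g-1

Three compounds sharing one core were tested in an in vitro ADME assay on microsomes from liver (Rattus norvegicus) for metabolic stability, read by LC-MS, tested at 1 uM; a lower number here means slower removal, a higher number faster removal of the compound. For compound 1 the result is a limit of the assay, < 10 mL.min-1.g-1. For compound 3 the result is also a limit, < 10 mL.min-1.g-1. Compound 2 is the only one of the three with an actual number, giving 18 mL.min-1.g-1 in this assay. Within the data shown here, the one direct comparison, an at least 1.8-fold higher number from compound 1 to compound 2 (0.25 log units; that floor lies within the scatter), cannot be sized beyond its floor, since the limit of < 10 mL.min-1.g-1 in this assay, at which 2 of the 3 values shown sit, hides where compound 1 truly lies.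

Compound 4, `Cc1ccc(S(=O)(=O)N2CCCCC2C)cc1C#Cc1cc(Cl)ccc1OCC(=O)O`, differs from compound 2 at the sulfonyl sulfur: 2-methylpiperidin-1-yl in place of methyl on a sulfonyl sulfur. The change brings back a nitrogen on the sulfonyl sulfur, as in compound 1 and compound 3, both sitting at the limit. Among the measured compounds shown here, that is thin evidence, and the only measured step has a floor within the scatter, so no step beyond the scatter is expected in this assay, with a lean toward a lower number. The estimate for compound 4 is 14 mL.min-1.g-1, with a range from 7 mL.min-1.g-1 to 30 mL.min-1.g-1, which means an expected step of a 1.3-fold lower number from compound 2 to compound 4 (0.11 log units; within the scatter).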

Compound 4, intrinsic clearance in microsomes: 418 mL.min-1.g-1
For compound 4 the middle estimate is 30-fold (1.48 log units) below the measured one, and the stated range ends below it.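

The sulfonyl sulfur is a place where the substituent can change the result greatly in this assay: 2-methylpiperidin-1-yl in place of methyl gives a 23-fold higher number from compound 2 to compound 4 (1.37 log units; beyond the scatter). A nitrogen on the sulfonyl sulfur does not by itself go with a low number, since two groups attached through nitrogen still differ by an at least 41-fold higher number from compound 1 to compound 4 (1.62 log units; beyond the scatter). That step is only a floor, and its true size stays hidden: the limit of < 10 mL.min-1.g-1 in this assay, at which 2 of the 4 values shown sit.

The compounds shown do not separate the effect of the ring from that of the methyl on it, a question that piperidin-1-yl without the methyl, or morpholin-4-yl, at the same sulfur could address. Which part of compound 4 is attacked in the microsomes also stays open.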